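Chloromethyl in place of phenyl on compound 2

The compounds below may be only part of what the source reports. "The series", "measured", "known", "first", "only" and "open" are said of these compounds alone.

In a functional assay on 8505C cells (Homo sapiens) for cytotoxicity, read by sulforhodamine B assay, with a stated time of 96 h (on this read-out lower numbers stand for an effect already at smaller amounts and higher numbers for an effect only at larger amounts of compound), compound 1 (`CCCC(=O)CC/C=C/C=C/C#CC#C/C=C/COC(C)=O`) gives 15600 nM and compound 2 (`CCCC(=O)CC/C=C/C=C/C#CC#C/C=C/COC(=O)c1ccccc1`) gives 4200 nM, the lower of the two numbers. Compound 3 (`CCCC(=O)CC/C=C/C=C/C#CC#C/C=C/COC(=O)CCl`) has not yet been measured. It carries chloromethyl in place of phenyl on a carbonyl carbon, and the counted difference from compound 2 is chloromethyl in place of phenyl on a carbonyl carbon.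

For the measured compounds named here, only one measured step bears on this change: a 3.7-fold lower number from compound 1 to compound 2 (0.57 log units; beyond the scatter), a modest step that came with phenyl in place of methyl on a carbonyl carbon. Compound 3 lacks the phenyl, as compound 1 does, so it is expected to give back part of that step and to fall between compound 2 and compound 1 at 15600 nM. Going by the values given here, no measured compound carries chlorine, so the size of the return is uncertain and the range is kept wide.

The expected move in this assay is toward a higher number, smaller than the step that came with phenyl in place of methyl: a 2.1-fold higher number from compound 2 to compound 3 (0.33 log units; beyond the scatter). For compound 3 the estimated value is 9000 nM, with an expected range of 3000 nM to 22000 nM.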

Compound 3, half-maximal effective concentration: 19300 nM
Estimate against measurement, compound 3: 2.1-fold (0.33 log units) below; the range from low to high includes it.
By their numbers in this assay, from the lowest: compound 2; then compounds 1 and 3 (each within the scatter of the next).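

In this assay, chloromethyl in place of phenyl on the carbonyl carbon gives a 4.6-fold higher number from compound 2 to compound 3 (0.66 log units; beyond the scatter) and so removes the whole advantage that compound 2 held over compound 1, showing that the lower number depends on the phenyl and is not retained by a second, different replacement of it. The step for chloro in place of hydrogen on a saturated chain carbon bound to a carbonyl carbon is a 1.2-fold higher number from compound 1 to compound 3 (0.09 log units; within the scatter) and does not separate the two compounds, so among these three groups on the carbonyl carbon, only phenyl gives a number set apart from the others, while methyl and chloromethyl cannot be told apart in this assay. No measurement here accounts for the difference between phenyl and the two smaller groups.

On these data alone, it remains open whether the effect needs an aromatic ring or only a larger carbon group, a question that cyclohexyl or a longer alkyl chain on the same carbonyl carbon would address. As far as these compounds go, it is also open whether a methoxy or amino group on the phenyl ring would take the number further down from that of compound 2.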